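The source may report more compounds than this note shows. Statements on the series, on what has been measured and on what is new or still open speak of the compounds shown alone.

Three of these compounds have been tested in a functional assay on COLO 320 cells (Homo sapiens) for antiproliferative activity, read by WST assay, with a stated time of 72 h (a lower number here means a stronger inhibitor, a higher number a weaker inhibitor), and a fourth awaits the same test. Compound 1 `Clc1ccc(-c2noc(-c3cc4cc(Cl)ccc4[nH]3)n2)cc1` gives 25000 nM. Compound 2 `Cn1c(-c2nc(-c3ccc(Cl)cc3)no2)cc2cc(Cl)ccc21` is set apart from compound 1 by a single change, (methyl in place of hydrogen on an aromatic nitrogen), and in this assay compound 2 gives 16900 nM; the step of a 1.5-fold lower number from compound 1 to compound 2 (0.17 log units; within the scatter). Compound 3 `COc1ccc(-c2noc(-c3cc4ccccc4[nH]3)n2)cc1` is built on a different core from compound 1, and the difference between the two cores is not broken down here. In this assay compound 3 gives 27700 nM, a value that sits among those of compound 1 and compound 2 with no separation beyond the scatter.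

Compound 4 `COc1ccc(-c2noc(-c3cc4ccccc4n3C)n2)cc1` has not yet been measured. It stands to compound 3 as compound 2 stands to compound 1: methyl in place of hydrogen on an aromatic nitrogen. The place of the change is described in the same words in both pairs, so the change is the same, and it occurs twice among these four compounds. Its one measured outcome, the step between compound 1 and compound 2, was within the scatter, and nothing in the data suggests the second core would respond differently. The expected step is therefore a 1.5-fold lower number from compound 3 to compound 4 (0.16 log units; within the scatter), a small shift of the same kind and size as the measured one. Compound 4 is accordingly estimated at 19000 nM in this assay, with a likely range from 9000 nM to 45000 nM.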

Compound 4, half-maximal inhibitory concentration: > 50000 nM
Compound 4: only a limit was reported; the forecaster's own chance of this, stated with the estimate: 10%; at least 2.6-fold (0.42 log units) between middle value and limit.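

In this assay, compound 4 gives > 50000 nM, which is a limit of the assay and not a number. Methyl in place of hydrogen on the aromatic nitrogen therefore gives an at least 1.8-fold higher number from compound 3 to compound 4 (0.25 log units; that floor lies within the scatter), and this is a floor rather than a measured size, so the true size of the step remains unknown. The result shows that the change can be read on both cores only loosely, and it establishes neither that the change carries over from one core to the other unchanged nor that it behaves differently on the second core, as the comparison of the two steps makes plain: the same change on two cores in this assay, a 1.5-fold lower number (0.17 log units; within the scatter) from compound 1 to compound 2 and an at least 1.8-fold higher number (0.25 log units; that floor lies within the scatter) from compound 3 to compound 4; the limit leaves it open whether they differ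

The compounds shown leave open how far past its limit compound 4 lies, and whether the same change could be read more sharply on a core whose values sit clear of that limit. They also leave open what a longer chain such as ethyl on the aromatic nitrogen, or an amine or a carboxylic acid in place of the chlorine or the methoxy group, would give in this assay.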